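Terminal amine versus hydroxyl on the long amide chain

A few compounds are considered here, and "the series" means these few. Any claim that something is new, unique, unknown or untested is made for them only; others in the source may bear on it.

Compound 1, `NCCCCCCCCCCCC(=O)Nc1cn(-c2ccccc2)nc1-c1ccccc1`, gives in a functional assay on U-87MG ATCC cells (Homo sapiens) for cytotoxicity, read by MTT assay, with a stated time of 24 h (a higher number here means a weaker inhibitor, a lower number a stronger inhibitor), a value of 77000 nM. Compound 2, `O=C(CCCCCCCCCCO)Nc1cn(-c2ccccc2)nc1-c1ccccc1`, is the counterpart carrying a hydroxyl end group. In this assay compound 2 returns only a limit, > 150000 nM. That limit is the one noted at the limit of > 150000 nM in this assay, at which 1 of the 3 values shown sits. The change from compound 1 to compound 2 is hydroxy in place of aminomethyl on a saturated chain carbon, ten or more bonds along the chain from a carbonyl carbon, and it produced an at least 1.9-fold higher number from compound 1 to compound 2 (0.28 log units; that floor lies within the scatter).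

Compound 3, `Cn1cc(NC(=O)CCCCCCCCCCCN)c(-c2ccccn2)n1`, carries a different core; in this assay compound 3 gives 90000 nM, a value within the scatter of compound 1. The difference between the two cores is not broken down here.

Compound 4, `Cn1cc(NC(=O)CCCCCCCCCCO)c(-c2ccccn2)n1`, relates to compound 3 by hydroxy in place of aminomethyl on a saturated chain carbon, ten or more bonds along the chain from a carbonyl carbon, the same change as that from compound 1 to compound 2, at the same place along the chain.

For compound 4 the expected step is a 2.0-fold higher number from compound 3 to compound 4 (0.30 log units; within the scatter), resting on the step seen from compound 1 to compound 2, an at least 1.9-fold higher number from compound 1 to compound 2 (0.28 log units; that floor lies within the scatter), where the partner with the hydroxyl end reached only a limit. Compound 4 is therefore estimated at 180000 nM, with a likely range from 90000 nM to 400000 nM, and a fair chance that this assay again reports only a limit.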

Compound 4, half-maximal inhibitory concentration: > 150000 nM
Compound 4: only a limit was reported (the forecaster's own chance of this, stated with the estimate: 55%); the middle value lies beyond the limit too.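

In this assay, hydroxy in place of aminomethyl on a saturated chain carbon, ten or more bonds along the chain from a carbonyl carbon, gives an at least 1.6-fold higher number from compound 3 to compound 4 (0.22 log units; that floor lies within the scatter). The data fit the change carrying from one core to the other, but both steps are only floors within the scatter, so they establish no real shift on either core and no equal size across the two: the same change on two cores in this assay, an at least 1.9-fold higher number (0.28 log units; that floor lies within the scatter) from compound 1 to compound 2 and an at least 1.6-fold higher number (0.22 log units; that floor lies within the scatter) from compound 3 to compound 4; the limit leaves it open whether they differ Neither hydroxy compound has a number that fixes the top of its step, so the comparison between cores goes no further: the limit of > 150000 nM in this assay, at which 2 of the 4 values shown sit.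

Open questions remain about the true size of the step on each core and whether it depends on the core at all. Also open, going by these compounds, is how the read-out would respond to a carboxylic acid or a dimethylamine in place of the hydroxy, or to a shorter or longer chain on either core.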